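Carbamoyl in place of phenyl: compound 3 to compound 4

The source may report more compounds than this note shows. Statements on the series, on what has been measured and on what is new or still open speak of the compounds shown alone.

The series shares one core, varied so far only on an aromatic carbon. Compound 1 `O=c1c([C@@H]2C[C@H](c3ccccc3)ON2c2ccccc2)coc2ccc(F)cc12` gives 60000 nM in a functional assay on Caco-2 cells (Homo sapiens) for inhibition, read by sulforhodamine B assay, with a stated time of 48 h; on this read-out lower numbers stand for stronger inhibition and higher numbers for weaker inhibition. Compound 2 `Cc1ccc2occ([C@@H]3C[C@H](c4ccccc4)ON3c3ccccc3)c(=O)c2c1` gives 31700 nM in this assay. For compound 3 `O=c1c([C@@H]2C[C@H](c3ccccc3)ON2c2ccccc2)coc2ccccc12` the read-out in this assay is only a limit, > 60000 nM. The three measured steps are small: a 1.9-fold lower number from compound 1 to compound 2 (0.28 log units; within the scatter); a number no lower from compound 1 to compound 3 (the limit leaves the size open); an at least 1.8-fold higher number from compound 2 to compound 3 (0.27 log units; that floor lies within the scatter). Compound 3 thus stands at the edge of the measurable range with no number of its own, the one case under (the limit of > 60000 nM in this assay, at which 1 of the 3 values shown sits).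

Compound 4 `NC(=O)[C@H]1C[C@@H](c2coc3ccccc3c2=O)N(c2ccccc2)O1` differs from compound 3 in one place: carbamoyl in place of phenyl on a saturated ring carbon. Among the measured compounds shown here, none of the measured steps bears on this change; all three concern a substituent on an aromatic carbon of the core, whereas here the phenyl on the saturated ring carbon next to the ring oxygen gives way to carbamoyl. For the measured compounds named here, no step therefore sets a size or a direction for this assay, and with compound 3 itself known only as a limit the expectation is wide. Compound 4 is expected to give about 60000 nM, within 20000 nM to 200000 nM. The step of a number no higher from compound 3 to compound 4 (the limit leaves the size open) is expected to amount to nothing beyond the scatter, and there is a fair chance that compound 4 too is reported only as a limit.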

Compound 4, half-maximal inhibitory concentration: > 60000 nM
Compound 4 ended at the assay's limit (the forecaster's own chance of this, stated with the estimate: 60%); the middle value lies on the limit itself.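

In this assay, among the compounds shown here, compound 3 and compound 4 are each known only as a limit of the assay, so no step between them can be read, in size or in direction: the limit of > 60000 nM in this assay, at which 2 of the 4 values shown sit. The compounds shown leave open whether carbamoyl in place of phenyl on a saturated ring carbon changes the half-maximal inhibitory concentration at all.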